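Swapping the Benzamide Aryl Group of Compound 2

The compounds below may be only part of what the source reports. "The series", "measured", "known", "first", "only" and "open" are said of these compounds alone.

Among the measured compounds shown here, compound 2 `CNc1nc(Nc2ccc(C)c([N+](=O)[O-])c2)ncc1C(=O)Nc1cc(NC(=O)c2cccc(C(F)(F)F)c2)ccc1C` gives 52 nM in a functional assay on K562 cells (Homo sapiens) for antiproliferative activity, read by CellTiter-Glo and CCK-8 assay, with a stated time of 72 h (on this read-out lower numbers stand for stronger inhibition of growth and higher numbers for weaker inhibition of growth), the second highest of the three numbers measured so far. Compound 1 `Cc1ccc(Nc2ncc3c(n2)N(C)C(=O)N(c2cc(NC(=O)c4cccc(C(F)(F)F)c4)ccc2C)C3)cc1N(C)C` gives 28 nM, a number that lies within the scatter of compound 2. For the measured compounds named here, compound 3 `Cc1ccc(NC(=O)c2cccc(C(F)(F)F)c2)cc1NC(=O)c1cnc(Nc2ccc(C)c([N+](=O)[O-])c2)nc1` gives 380 nM, and the step of a 7.3-fold higher number from compound 2 to compound 3 (0.86 log units; beyond the scatter) is the only measured step; it concerns the other end of the molecule. Compound 4 `CNc1nc(Nc2ccc(C)c([N+](=O)[O-])c2)ncc1C(=O)Nc1cc(NC(=O)c2cc(OC)cc(OC)c2)ccc1C` differs from compound 2 by 3,5-dimethoxyphenyl in place of 3-(trifluoromethyl)phenyl on a carbonyl carbon. Going by the values given here, no measured step touches that position, so the expectation rests only on the remainder shared with compound 2. The step of a 3.8-fold higher number from compound 2 to compound 4 (0.59 log units; beyond the scatter) is therefore expected to be a modest rise in the number, with wide uncertainty. Compound 4 is estimated at 200 nM, with a range from 50 nM to 800 nM.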

Compound 4, concentration for 50% growth inhibition: 1070 nM
Compound 4: the middle estimate sits 5.4-fold (0.73 log units) below what was measured, and the stated range ends below it.
By their numbers in this assay, from the lowest: compounds 1 and 2 (each within the scatter of the next); then compound 3; then compound 4.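

Among the compounds shown here, at the benzamide aryl position, which no earlier step touched, this assay proves sensitive to the aryl group: replacing 3-(trifluoromethyl)phenyl with 3,5-dimethoxyphenyl gives a 21-fold higher number from compound 2 to compound 4 (1.31 log units; beyond the scatter). Both groups have 10 heavy atoms and one six-membered aromatic ring, yet the number still moves this far. Nothing in the available evidence accounts for this step.

The compounds shown do not separate the loss of trifluoromethyl from the entry of the two methoxy groups. As far as these compounds go, how a phenyl carrying a single methoxy, a nitrile or an amine would behave also remains open.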